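This account rests on a few compounds, and the source may have more. Where it says the series, first, only, none or still open, it means among the compounds named here.

Compound 1, `Nc1cccc(-c2ccc3nccc(-c4ccncc4)c3n2)c1`, is the reference point here. Going by the values given here, in an ADME assay on microsomes from liver (Homo sapiens) for metabolic stability, read by LC-MS, using NADPH, with a stated time of 30 min, tested at 0.1 uM (on this read-out lower numbers stand for a less stable compound and higher numbers for a more stable compound), compound 1 gives 78%, the higher of the two numbers measured so far. Among the compounds with values here, compound 2, `O=S(=O)(NCC1COC1)c1cccc(-c2ccc3nccc(-c4ccncc4)c3n2)c1`, gives 2% in this assay, and the step of a number 76 percentage points lower from compound 1 to compound 2 (beyond the scatter) is the only measured change available.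

Compound 3, `CS(=O)(=O)Nc1ccc2nccc(-c3ccncc3)c2n1`, differs from compound 1 in one place: methanesulfonamido in place of 3-aminophenyl on an aromatic carbon.

The step from compound 1 to compound 2 bears on this only loosely: it kept the ring and added a sulfonamide-type group, whereas the change to compound 3 removes that ring and places a smaller sulfonamide directly on the core. Because a number 76 percentage points lower from compound 1 to compound 2 (beyond the scatter) was large, a decrease for compound 3 is expected, but a smaller one than in that step; the expected step is a number 28 percentage points lower from compound 1 to compound 3 (beyond the scatter). Compound 3 is estimated to give 50% in this assay, within a range from 20% to 80%.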

Compound 3, percent of the compound remaining: 96%
The estimate for compound 3 lay 46 percentage points below the measured number, and the stated range ends below it.
By their numbers in this assay, from the lowest: compound 2; then compound 1; then compound 3.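

In this assay, the 3-aminophenyl group on this aromatic carbon next to the ring nitrogen is not needed for a high number: methanesulfonamido in its place gives a number 18 percentage points higher from compound 1 to compound 3 (beyond the scatter) and leaves no six-membered aromatic ring of carbon only. The earlier change, a number 76 percentage points lower from compound 1 to compound 2 (beyond the scatter), went the other way, so among these compounds carrying a sulfonamide-type group does not by itself fix the direction of the step. Nothing measured here explains the rise seen for compound 3.

Still open, going by these compounds, is whether the higher number comes from the methanesulfonamido group itself or from the loss of the 3-aminophenyl group; a plain amine on the same aromatic carbon would help separate the two. A longer chain on the sulfonyl group, such as propyl in place of methyl, would show whether the number holds.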